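The source may hold more compounds than are shown below. What is called first, only, known or untested is meant among the compounds shown, and "the series" means these compounds.

Compound 1 `C=C(Br)C(=O)Nc1cccc(-c2cn3nc(-c4ccccc4)sc3n2)c1` and compound 2 `C=C(Br)C(=O)Nc1cccc(-c2cn3nc(-c4ccc(C)cc4)sc3n2)c1` share a core, and in a functional assay on FM3A cells (Mus musculus) for inhibition, read by cell counting, with a stated time of 2 days (on this read-out lower numbers stand for stronger inhibition and higher numbers for weaker inhibition), compound 1 gives 900 nM, while compound 2 gives 1200 nM. The two differ in one place: methyl in place of hydrogen on an aromatic carbon. That change gave a 1.3-fold higher number from compound 1 to compound 2 (0.12 log units; within the scatter).

Compound 3 `Nc1cccc(-c2cn3nc(-c4ccccc4)sc3n2)c1` carries a different core, and the difference from compound 1 is hydrogen in place of (1-bromoethenyl)carbonyl on a nitrogen on an aromatic ring. In this assay compound 3 gives 14000 nM, and the step was a 16-fold higher number from compound 1 to compound 3 (1.19 log units; beyond the scatter), so compound 3 stands furthest from compound 1 among the three measured compounds.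

Compound 4 `Cc1ccc(-c2nn3cc(-c4cccc(N)c4)nc3s2)cc1` has not yet been measured in this assay. It differs from compound 3 by methyl in place of hydrogen on an aromatic carbon, and this is the same change that separates compound 2 from compound 1, made on the same place on the six-membered aromatic ring of carbon only, para to a large group. Among these compounds the change occurs twice in all, and the one measured instance of it, from compound 1 to compound 2, stayed within the scatter.

On this ground compound 4 is expected to give a number close to that of compound 3, and the expected step is a 1.2-fold higher number from compound 3 to compound 4 (0.08 log units; within the scatter), resting on compound 1 to compound 2 having given a 1.3-fold higher number from compound 1 to compound 2 (0.12 log units; within the scatter). The estimate for compound 4 in this assay is 17000 nM, expected to fall between 8000 nM and 35000 nM.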

Compound 4, half-maximal inhibitory concentration: 5800 nM
Compound 4: middle estimate off by 2.9-fold (0.47 log units), on the high side; measured number below the stated range.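

In this assay the methyl change did not carry over from one core to the other: on the cores with the free amine it gave a 2.4-fold lower number from compound 3 to compound 4 (0.38 log units; beyond the scatter), a step beyond the scatter, whereas on the cores bearing the (1-bromoethenyl)carbonyl group it stayed within the scatter: the same change on two cores in this assay, a 1.3-fold higher number (0.12 log units; within the scatter) from compound 1 to compound 2 and a 2.4-fold lower number (0.38 log units; beyond the scatter) from compound 3 to compound 4, 3.2-fold (0.51 log units) apart, beyond the scatter of two such steps Removing the (1-bromoethenyl)carbonyl group raised the number in both pairs, so the direction of that change held, but its size did not, with a 4.8-fold higher number from compound 2 to compound 4 (0.68 log units; beyond the scatter) being the smaller of the two steps: the same change on two cores in this assay, a 16-fold higher number (1.19 log units; beyond the scatter) from compound 1 to compound 3 and a 4.8-fold higher number (0.68 log units; beyond the scatter) from compound 2 to compound 4, 3.2-fold (0.51 log units) apart, beyond the scatter of two such steps Both gaps rest on the same four compounds, so they are a single observation seen from two sides, and they show that the two changes do not simply add up in this set, but not why, nor how either change would behave on any other core.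

From the compounds shown here alone, it remains open whether a chlorine, a methoxy group or an ethyl group in place of the methyl on the six-membered aromatic ring would follow compound 4 or compound 2. Going by these compounds, it also remains open whether a plain acetyl group on the nitrogen would give numbers nearer those of compound 1 and compound 2 or those of compound 3 and compound 4.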